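This account rests on a few compounds, and the source may have more. Where it says the series, first, only, none or still open, it means among the compounds named here.

Two urea-linked compounds have been measured. Compound 1 `CCOC(=O)c1ccc(NC(=O)NCc2ccnnc2)cc1` gives only a limit in an assay on isolated protein for activation of Nicotinamide phosphoribosyltransferase (Homo sapiens) (on this read-out lower numbers stand for an effect already at smaller amounts and higher numbers for an effect only at larger amounts of compound), namely > 100000 nM. Compound 2 `CCN(C1CCCC1)S(=O)(=O)c1ccc(NC(=O)NCc2ccncc2)cc1` gives 60 nM in this assay. Within the data shown here, that is the only true number so far; the other result is the limit (the limit of > 100000 nM in this assay, at which 1 of the 2 values shown sits). Compound 3 `CCN(CC)S(=O)(=O)c1ccc(NC(=O)NCc2ccncc2)cc1` differs from compound 2 by ethyl in place of cyclopentyl on a sulfonamide nitrogen. Among the measured compounds shown here, no measured pair differs in one place, so no measured step gives a scale for this change. The step of a 2.0-fold higher number from compound 2 to compound 3 (0.30 log units; within the scatter) is expected to be small, leaning towards larger amounts, and close to the usual scatter. Compound 3 is expected to give about 120 nM in this assay, between 40 nM and 400 nM.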

Compound 3, half-maximal effective concentration: 384 nM
Compound 3: middle estimate off by 3.2-fold (0.51 log units), on the low side; low and high end bracket the measured number.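

Exchanging cyclopentyl(ethyl)amino for diethylamino gives a 6.4-fold higher number from compound 2 to compound 3 (0.81 log units; beyond the scatter) in this assay. Among these compounds, this is the first measured step between compounds that differ in one place, and it shows that the group at this position can shift the result beyond the usual scatter. No measurement shown explains this step.

Going by these compounds, what remains open is whether the ring itself matters or only the number of carbons in the group. An open pentyl chain, with the same count of carbons as cyclopentyl but no ring, would help separate these two possibilities.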